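Swapping the aryl group on the compound 3 scaffold

The source may hold more compounds than are shown below. What is called first, only, known or untested is meant among the compounds shown, and "the series" means these compounds.

In a functional assay on HCT-116 cells (Homo sapiens) for inhibition, with a stated time of 72 h (on this read-out higher numbers stand for weaker inhibition and lower numbers for stronger inhibition), compound 1 (`NC1CCC(Nc2nc(NCc3ccc(-c4cccc(F)c4)nc3)c3ncn(C4CCCC4)c3n2)CC1`) gives 74 nM, compound 2 (`NC1CCC(Nc2nc(NCc3ccc(-c4ccco4)nc3)c3ncn(C4CCCC4)c3n2)CC1`) gives 86 nM and compound 3 (`NC1CCC(Nc2nc(NCc3ccc(-c4cccs4)nc3)c3ncn(C4CCCC4)c3n2)CC1`) gives 97 nM. Compound 3 cannot be told apart from the other two on these numbers: the steps are a 1.3-fold higher number from compound 1 to compound 3 (0.12 log units; within the scatter) and a 1.1-fold higher number from compound 2 to compound 3 (0.05 log units; within the scatter), both within the scatter.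

Compound 4 (`NC1CCC(Nc2nc(NCc3ccc(-c4ccccc4O)nc3)c3ncn(C4CCCC4)c3n2)CC1`) has 2-hydroxyphenyl in place of thiophen-2-yl on an aromatic carbon, (2-hydroxyphenyl in place of thiophen-2-yl on an aromatic carbon). The measured steps all exchange the group at this same place. Besides the two above, there is a 1.2-fold higher number from compound 1 to compound 2 (0.07 log units; within the scatter), also within the scatter. Those three groups therefore leave the read-out flat, and that includes the exchange of a six-membered ring for a five-membered one in a 1.3-fold higher number from compound 1 to compound 3 (0.12 log units; within the scatter). Among the measured compounds shown here, no measured compound carries a hydroxyl group here, so that part of the change is untested, and the range is kept wide.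

No shift beyond the scatter is expected in this assay, and the expected change is a 1.1-fold lower number from compound 3 to compound 4 (0.03 log units; within the scatter). For compound 4 the estimate is 90 nM, with an expected range of 35 nM to 250 nM.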

Compound 4, half-maximal inhibitory concentration: 35 nM
For compound 4 the middle estimate is 2.6-fold (0.41 log units) above the measured one; the range from low to high includes it.
By their numbers in this assay, from the lowest: compound 4; then compounds 1, 2 and 3 (each within the scatter of the next).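

In this assay this position is not flat after all: 3-fluorophenyl, furan-2-yl and thiophen-2-yl could not be told apart, whereas 2-hydroxyphenyl gives a 2.8-fold lower number from compound 3 to compound 4 (0.44 log units; beyond the scatter), a 2.5-fold lower number from compound 2 to compound 4 (0.39 log units; beyond the scatter) and a 2.1-fold lower number from compound 1 to compound 4 (0.33 log units; beyond the scatter), each modest but beyond the scatter. Compound 1 already carries a six-membered aromatic ring and its step still lies beyond the scatter, so ring size alone does not separate compound 4 from the other three. Nothing available explains why this group gives the lower number.

On these data alone, whether the hydroxyl group itself is what matters stays open, and a 2-methoxyphenyl or 2-aminophenyl group at this place would speak to that. Among the compounds shown here, how far the shift can go also remains open, since the only step beyond the scatter at this position so far comes from this one group.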